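This account rests on a few compounds, and the source may have more. Where it says the series, first, only, none or still open, it means among the compounds named here.

Measured so far:
- compound 1, `[N-]=[N+]=N[C@@H]1C(n2ccc(=O)[nH]c2=O)[Se][C@H](CO)[C@H]1O`. In a functional assay on PC-3 cells (Homo sapiens) for cytotoxicity, read by sulforhodamine B assay (a lower number here means a stronger inhibitor, a higher number a weaker inhibitor), compound 1 gives > 100000 nM, which is a limit of the assay and not a number.
- compound 2, `O=c1ccn(C2[Se][C@H](CO)[C@@H](O)[C@@H]2O)c(=O)[nH]1`. In this assay compound 2 gives > 100000 nM, again a limit rather than a number.
- compound 3, `[N-]=[N+]=N[C@@H]1C(n2ccc(N)nc2=O)[Se][C@H](CO)[C@H]1O`. In this assay compound 3 gives 75100 nM.

Compound 1 and compound 2 differ in one place: hydroxy in place of azido on a saturated ring carbon. The step that the two limits leave unreadable from compound 1 to compound 2 cannot be read, since both ends are limits. Going by the values given here, compound 3 carries the only number in the set; its core is not the core of compound 1, and the difference between the two cores is not broken down here. What stands out is the limit of > 100000 nM in this assay, at which 2 of the 3 values shown sit, so the set as a whole sits at the weak end of the window.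

Compound 4, `Nc1ccn(C2[Se][C@H](CO)[C@@H](O)[C@@H]2O)c(=O)n1`, is not yet measured. It differs from compound 3 by hydroxy in place of azido on a saturated ring carbon. The place around this change is described in the same words as for the step from compound 1 to compound 2, so it is the same change made a second time, now on the core of compound 3.

For the expected size, the step of a 2.0-fold higher number from compound 3 to compound 4 (0.30 log units; within the scatter) is set beside a step that the two limits leave unreadable from compound 1 to compound 2 as an estimate with little to lean on, because a step that the two limits leave unreadable from compound 1 to compound 2 gives no readable size and compound 3 itself sits close to the window edge at 75100 nM. On that basis compound 4 is expected to come out near 150000 nM in this assay, with the likely span estimated as 50000 nM to 500000 nM, and a fair chance that only a limit is reported.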

Compound 4, half-maximal inhibitory concentration: 4540 nM
Compound 4: the middle estimate sits 33-fold (1.52 log units) above what was measured, and the stated range ends above it.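

In this assay, going by these compounds alone, hydroxy in place of azido on a saturated ring carbon gives a 17-fold lower number from compound 3 to compound 4 (1.22 log units; beyond the scatter), a large step and the only readable instance of this change. The same change on the core of compound 1 cannot be read, since compound 1 and compound 2 are each reported only as a limit of the assay and not as a number, and such limits recur in the set: the limit of > 100000 nM in this assay, at which 2 of the 4 values shown sit. The change therefore carries a large step on the core of compound 3, but nothing shows whether a step of similar size, a smaller one or none at all occurs on the core of compound 1, so transfer between the two cores is neither supported nor contradicted.

The compounds shown leave open how an amine or a fluoro group on this saturated ring carbon would compare with hydroxy and azido on either core. They also leave open whether a longer chain in place of the hydroxymethyl group would shift the result for compound 4 in this assay.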